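A few compounds are considered here, and "the series" means these few. Any claim that something is new, unique, unknown or untested is made for them only; others in the source may bear on it.

Compound 1 `COc1cc2ncnc(Nc3ccc(F)c(Cl)c3)c2cc1NC(=O)N/N=C/c1ccc(F)cc1Cl`: "not active" (no number reported)
Compound 2 `COc1ccc(/C=N/NC(=O)Nc2cc3c(Nc4ccc(F)c(Cl)c4)ncnc3cc2OC)cc1`: 8140 nM

Among the measured compounds shown here, in a functional assay on MCF7 cells (Homo sapiens) for cytotoxicity, read by MTT assay, with a stated time of 72 h (a higher number here means a weaker inhibitor, a lower number a stronger inhibitor), compound 2 holds the only number, 8140 nM, while compound 1 yielded none and reads "not active" (no number reported). Compound 3 `COc1cc2ncnc(Nc3ccc(F)c(Cl)c3)c2cc1NC(=O)N/N=C/c1ccc(O)cc1O` comes next. The change is 2,4-dihydroxyphenyl in place of 4-methoxyphenyl on a carbon with a double bond to nitrogen. No measured step sizes this swap, so no move beyond the scatter in this assay is expected, with only a slight lean towards a stronger inhibitor. The expected change is a 1.6-fold lower number from compound 2 to compound 3 (0.21 log units; within the scatter). Compound 3 is estimated at 5000 nM, within a range of 1500 nM to 20000 nM.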

Compound 3, half-maximal inhibitory concentration: 36200 nM
The estimate for compound 3 lay 7.2-fold (0.86 log units) below the measured number; measured number outside the range, above it.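

In this assay, among the compounds shown here, the swap of 4-methoxyphenyl for 2,4-dihydroxyphenyl on a carbon with a double bond to nitrogen gives a 4.4-fold higher number from compound 2 to compound 3 (0.65 log units; beyond the scatter) and so provides the first sized step at this position. The number responds to this change even though the two groups have the same heavy-atom count. Nothing available accounts for the shift. The compounds shown leave open whether a single hydroxy group would produce the same step, and how an amine or a carboxylic acid on that ring would read.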